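A few compounds are considered here, and "the series" means these few. Any claim that something is new, unique, unknown or untested is made for them only; others in the source may bear on it.

Compound 2 `Cc1cccc(N2CCN(C(=O)CN3C(=O)CC(C)C3=O)CC2)c1` has the lowest of the two numbers in a functional assay on the whole organism (strain CD1) with Mus musculus as the target, with a stated time of 0.5 h (a higher number here means that more compound is needed for the effect, a lower number that less compound is needed), where compound 2 gives 100 mg/kg; its nearest neighbour is compound 1 `CC1CC(=O)N(CC(=O)N2CCN(c3ccccc3)CC2)C1=O`, which in this assay gives 300 mg/kg. Among the measured compounds shown here, the one measured step, a 3.0-fold lower number from compound 1 to compound 2 (0.48 log units; beyond the scatter), concerns methyl in place of hydrogen on an aromatic carbon. Compound 3 `CC1CC(=O)N(CC(=O)N2CCN(c3ccccc3Cl)CC2)C1=O` differs from compound 2 by 2-chlorophenyl in place of 3-methylphenyl on an amine nitrogen in a ring. For the measured compounds named here, no measured step covers a chlorine for a methyl or a shift from 3-position to 2-position, so the estimate rests on the spread between compound 1 and compound 2 alone. Compound 3 is therefore expected to land near them, as a step of a 1.5-fold higher number from compound 2 to compound 3 (0.18 log units; within the scatter), with an estimated value of 150 mg/kg between 50 mg/kg and 600 mg/kg.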

Compound 3, minimum effective dose: 300 mg/kg
The estimate for compound 3 lay 2.0-fold (0.30 log units) below the measured number; the measured number falls inside the stated range.
By their numbers in this assay, from the lowest: compound 2; then compounds 1 and 3 (each within the scatter of the next).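

The step of a 3.0-fold higher number from compound 2 to compound 3 (0.48 log units; beyond the scatter) in this assay shows that the lower number of compound 2 does not carry over to every substituted phenyl on this amine nitrogen. The step of no change at the digits printed from compound 1 to compound 3 (within the scatter) shows that chloro in place of hydrogen, in contrast to the methyl step, does not separate the two compounds. Nothing measured here bears on why methyl and chloro differ in this way.

The compounds shown leave open whether the step follows the chlorine or its place in 2-chlorophenyl rather than 3-methylphenyl. They also leave open how 3-chlorophenyl, 2-methylphenyl or an aminophenyl group would read.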